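Chain-end variation on a TRPV1 antagonist quinazoline series

The source may report more compounds than this note shows. Statements on the series, on what has been measured and on what is new or still open speak of the compounds shown alone.

Compounds measured so far, with their numbers in a functional assay for antagonist activity at transient receptor potential cation channel subfamily V member 1 (Homo sapiens); a lower number here means a stronger inhibitor, a higher number a weaker inhibitor:
Compound 1, `OCCc1nc(Nc2ccc(C(F)(F)F)cc2)c2ccc(-c3ncccc3C(F)(F)F)cc2n1`: 22 nM
Compound 2, `OCCCc1nc(Nc2ccc(C(F)(F)F)cc2)c2ccc(-c3ncccc3C(F)(F)F)cc2n1`: 25 nM
Compound 3, `CS(=O)(=O)CCc1nc(Nc2ccc(C(F)(F)F)cc2)c2ccc(-c3ncccc3C(F)(F)F)cc2n1`: 36 nM

Compound 3 has the highest of the three numbers, but its gaps to compound 2 and to compound 1 both lie within the scatter, so no order among the three can be read from these values. The three measured steps, a 1.1-fold higher number from compound 1 to compound 2 (0.06 log units; within the scatter), a 1.6-fold higher number from compound 1 to compound 3 (0.21 log units; within the scatter) and a 1.4-fold higher number from compound 2 to compound 3 (0.16 log units; within the scatter), all sit inside the scatter: hydroxy, hydroxymethyl and methylsulfonyl at the same chain position give the same result within the usual spread.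

Compound 4, `FC(F)(F)c1ccc(Nc2nc(CNC3CCCCC3)nc3cc(-c4ncccc4C(F)(F)F)ccc23)cc1`, is not yet measured. It differs from compound 3 by cyclohexylamino in place of (methylsulfonyl)methyl on a saturated chain carbon bound to an aromatic carbon. For the measured compounds named here, none of the measured steps covers this change; they only show that exchanging one uncharged group for another on this chain left the number unmoved, while compound 4 brings in a ring and a hydrogen-bond donor at the nitrogen. The steps that exist therefore give no ground to expect a shift beyond the scatter, but the change is larger than any of them, so the range is set wide.

Compound 4 is expected to give 40 nM, between 12 nM and 140 nM, which means an expected 1.1-fold higher number from compound 3 to compound 4 (0.05 log units; within the scatter).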

Compound 4, half-maximal inhibitory concentration: 6 nM
Beside the measured number, compound 4's estimate is 6.7-fold (0.82 log units) above it, outside the stated range (below it).
By their numbers in this assay, from the lowest: compound 4; then compounds 1, 2 and 3 (each within the scatter of the next).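

In this assay the saturated chain carbon bound to an aromatic carbon turns out to be a place where the group can move the number beyond the scatter: cyclohexylamino gives a 6.0-fold lower number from compound 3 to compound 4 (0.78 log units; beyond the scatter) and, against the hydroxy-bearing chains, a 4.2-fold lower number from compound 2 to compound 4 (0.62 log units; beyond the scatter) and a 3.7-fold lower number from compound 1 to compound 4 (0.56 log units; beyond the scatter) in the same direction. Exchanges among the hydroxy, hydroxymethyl and methylsulfonyl chain ends had stayed within the scatter, so among the compounds shown only this change, which brings in both a six-membered carbon ring and a nitrogen with a hydrogen-bond donor, separates one compound from the rest. No measurement bears on why the number falls with this group.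

The compounds shown leave open whether the ring or the nitrogen carries the step, and the answer would need a smaller amine such as methylamino, or a cyclohexyloxy or cyclohexylmethyl group in the same place. They also leave open how a piperidine, with the nitrogen inside the ring, or a longer chain between the core and the cyclohexylamino group would read in this assay on this core.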